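This account rests on a few compounds, and the source may have more. Where it says the series, first, only, none or still open, it means among the compounds named here.

Compound 2 `CCCS(=O)(=O)Nc1ccc(F)c(C(=O)c2n[nH]c3ncc(-c4cc(Cl)cc(Cl)c4)cc23)c1F` and compound 1 `CCCS(=O)(=O)Nc1ccc(F)c(C(=O)c2n[nH]c3ncc(-c4cccc(N)c4)cc23)c1F` share one core and differ only in the group on the bicyclic ring. In an assay for binding affinity to dual specificity mitogen-activated protein kinase kinase 4 (Homo sapiens), read by KINOMEscan, tested at 100 nM (a higher number here means a weaker effect of the compound at the concentration tested, a lower number a stronger effect), compound 2 gives 73%, the higher of the two numbers, while compound 1 gives 1.6%. Among the measured compounds shown here, the single measured step, a number 71.4 percentage points higher from compound 1 to compound 2 (beyond the scatter), shows how much this position matters. Compound 3 `CCCS(=O)(=O)Nc1ccc(F)c(C(=O)c2n[nH]c3ncc(-c4ccc(-c5nnn[nH]5)cc4)cc23)c1F` carries a further change at the same place: 4-(1H-tetrazol-5-yl)phenyl in place of 3,5-dichlorophenyl on an aromatic carbon. For the measured compounds named here, the new group, with its hydrogen-bond donor and acceptors, lies closer to the polar aminophenyl of compound 1 than to the dichlorophenyl of compound 2, so a downward step a number 43 percentage points lower from compound 2 to compound 3 (beyond the scatter) is expected, though only one step supports it. Compound 3 is estimated at 30%, within 3% to 85%.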

Compound 3, a percentage reported as activity, at one concentration (the size of the read-out at that concentration, not a potency): 0.15%
Beside the measured number, compound 3's estimate is 29.9 percentage points above it; the whole stated range lies above it.
By their numbers in this assay, from the lowest: compounds 3 and 1 (each within the scatter of the next); then compound 2.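

The low number of compound 1 is not unique to 3-aminophenyl: 4-(1H-tetrazol-5-yl)phenyl, with its added five-membered ring, gives a number 1.5 percentage points lower from compound 1 to compound 3 (within the scatter) in this assay. Against 3,5-dichlorophenyl, the same group gives a number 72.9 percentage points lower from compound 2 to compound 3 (beyond the scatter) and so, among these three groups, only 3,5-dichlorophenyl stands apart. Nothing available explains this difference.

Still open, going by these compounds, is which feature of the two low-number groups matters, and whether a phenyl carrying a carboxylic acid would behave like them. A single chlorine on the phenyl ring could show whether one halogen is enough to raise the number.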